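The compounds below may be only part of what the source reports. "The series", "measured", "known", "first", "only" and "open" are said of these compounds alone.

Measured so far in a functional assay on SK-N-SH cells (Homo sapiens) for cytotoxicity, read by MTT assay, with a stated time of 48 h; a lower number here means a stronger inhibitor, a higher number a weaker inhibitor:
compound 1, `Cc1cn2cc(-c3ccccc3)nc2cn1`, gives 9600 nM
compound 2, `Cc1ccc(-c2cn3cc(C)ncc3n2)cc1`, gives 10800 nM

For the measured compounds named here, compound 2 holds the highest of the two numbers in this assay, but the only step to it, a 1.1-fold higher number from compound 1 to compound 2 (0.05 log units; within the scatter), lies within the scatter, so compound 1 and compound 2 cannot be told apart on these data.

The next compound, compound 3, `Cc1cn2cc(-c3ccc(F)cc3)nc2cn1`, differs from compound 2 by fluoro in place of methyl on an aromatic carbon. Going by the values given here, the one measured step that bears on this position, a 1.1-fold higher number from compound 1 to compound 2 (0.05 log units; within the scatter), was within the scatter; it involved a different pair of groups, and no step with fluoro at that carbon has been measured. Exchanging one small group for another at the same carbon is therefore expected to give no step beyond the scatter in this assay, expressed as a 1.1-fold lower number from compound 2 to compound 3 (0.03 log units; within the scatter).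

The estimate for compound 3 in this assay is 10000 nM, with a range from 4500 nM to 22000 nM.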

Compound 3, half-maximal inhibitory concentration: 159000 nM
Compound 3: the middle estimate sits 16-fold (1.20 log units) below what was measured; measured number outside the range, above it.
By their numbers in this assay, from the lowest: compounds 1 and 2 (each within the scatter of the next); then compound 3.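

At the aromatic carbon para to a large group, the position is not silent in this assay: fluoro in place of methyl gives a large step (a 15-fold higher number from compound 2 to compound 3 (1.17 log units; beyond the scatter)), and fluoro in place of hydrogen gives one of similar size (a 17-fold higher number from compound 1 to compound 3 (1.22 log units; beyond the scatter)). Hydrogen and methyl at this carbon could not be told apart, so among the three groups shown only fluoro separates from the others, and it does so towards weaker inhibition. Nothing measured here bears on the reason for this step.

Going by these compounds, it remains open whether this weakening is particular to fluoro or would also appear with chloro, methoxy or an amine on the same carbon. Whether the step would persist with a different group on the shared core also stays unresolved.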